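Swapping Bromo for Methyl on a Different Core

The compounds below may be only part of what the source reports. "The series", "measured", "known", "first", "only" and "open" are said of these compounds alone.

Measured so far:
Compound 1, `O=C1/C(=C/c2cccc(Br)c2)CCCc2ccccc21`: 10500 nM
Compound 2, `Cc1cccc(/C=C2\CCCc3ccccc3C2=O)c1`: 19900 nM
Compound 3, `O=C1CCCCC/C1=C\c1ccc(Br)cc1`: 16800 nM

All three were tested in a functional assay on P388 cells (Mus musculus) for inhibition; on this read-out higher numbers stand for weaker inhibition and lower numbers for stronger inhibition. Compound 1 carries a bromo group on its aromatic ring; compound 2 has a methyl group in its place, the difference being (methyl in place of bromo on an aromatic carbon). That swap gave a 1.9-fold higher number from compound 1 to compound 2 (0.28 log units; within the scatter). Compound 3 sits on a different core; the difference between the two cores is not broken down here. Its value in this assay lies close to those of compound 1 and compound 2, with all gaps within the scatter.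

Compound 4, `Cc1ccc(/C=C2\CCCCCC2=O)cc1`, has not yet been measured. It differs from compound 3 by methyl in place of bromo on an aromatic carbon. Among the compounds with values here, this is the same kind of change as the one from compound 1 to compound 2, but the place is not identical: in the first pair the methyl sits meta to a large group, while in compound 4 it sits para to a group of 9 heavy atoms. Since the earlier swap gave a 1.9-fold higher number from compound 1 to compound 2 (0.28 log units; within the scatter), a step of roughly that size, expected as a 1.7-fold higher number from compound 3 to compound 4 (0.22 log units; within the scatter), seems reasonable for compound 4 in this assay, though the different core and placement leave the outcome uncertain. Compound 4 is therefore estimated at 28000 nM, with a likely range from 12000 nM to 65000 nM.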

Compound 4, half-maximal inhibitory concentration: > 50000 nM
Compound 4: a limit, no number; the forecaster's own chance of this, stated with the estimate: 15%; middle value at least 1.7-fold (0.25 log units) away from the limit.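

In this assay compound 4 gives > 50000 nM, which is a limit of the assay and not a number. On this second core, methyl in place of bromo gives an at least 2.9-fold higher number from compound 3 to compound 4 (0.47 log units; beyond the scatter), so here the swap produces a real loss of inhibition rather than a shift within the scatter of repeat measurements. What this does not show is whether the change has the same size on both cores, and two pairs are too few to make a rule for the series: the same change on two cores in this assay, a 1.9-fold higher number (0.28 log units; within the scatter) from compound 1 to compound 2 and an at least 2.9-fold higher number (0.47 log units; beyond the scatter) from compound 3 to compound 4; the limit leaves it open whether they differ

As far as these compounds go, the full size of the step on this second core stays open, as the result for compound 4 gives only a limit, and the same holds for whether bromo and methyl would compare in the same way if they sat at the same place on both cores. Also open, from the compounds shown here alone, is how other groups on the aromatic ring, such as chloro, methoxy or an amine, would behave on either core, and whether any of them would keep the inhibition seen with bromo.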